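Replacing phenyl with ethyl in compound 2

This account rests on a few compounds, and the source may have more. Where it says the series, first, only, none or still open, it means among the compounds named here.

Compound 1 `C#CC(O/C=C/C(=O)OC)c1ccccc1` gives 31000 nM
Compound 2 `COC(=O)C#CC(O/C=C/C(=O)OC)C(C)c1ccccc1` gives 1200 nM
Compound 3 `Cc1ccc(S(=O)(=O)C#CC(O/C=C/S(=O)(=O)c2ccc(C)cc2)C(C)C)cc1` gives 3200 nM

In a functional assay on SW1573 cells (Homo sapiens) for antiproliferative activity, read by sulforhodamine B assay, with a stated time of 48 h (on this read-out higher numbers stand for weaker inhibition of growth and lower numbers for stronger inhibition of growth), compound 2 stands lowest at 1200 nM and lies beyond the scatter from both compound 3 and compound 1, which makes it the strongest inhibitor of growth of the three. Compound 4 `CCC(C)C(C#CC(=O)OC)O/C=C/C(=O)OC` differs from compound 2 by ethyl in place of phenyl on a saturated chain carbon bound to two saturated chain carbons in the side chain, with ethyl in place of phenyl on a saturated chain carbon bound to two saturated chain carbons. Within the data shown here, no measured pair isolates this change, and the expectation is therefore loose. A modest move toward weaker inhibition of growth is expected in this assay, with a 2.1-fold higher number from compound 2 to compound 4 (0.32 log units; beyond the scatter) as the estimated step. The estimated value for compound 4 is 2500 nM with an expected range from 800 nM to 8000 nM on this reasoning.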

Compound 4, concentration for 50% growth inhibition: 910 nM
Compound 4: the middle estimate sits 2.7-fold (0.44 log units) above what was measured, and the stated range covers the measured number.
By their numbers in this assay, from the lowest: compounds 4 and 2 (each within the scatter of the next); then compound 3; then compound 1.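

In this assay, ethyl in place of phenyl on a saturated chain carbon bound to two saturated chain carbons gives (a 1.3-fold lower number from compound 2 to compound 4 (0.12 log units; within the scatter)). Among these compounds, this is the first pair that isolates a single change, and it shows that the number stays within the scatter when the aromatic ring at this place is lost, so phenyl is not needed here to hold this level of growth inhibition. Nothing at hand offers an explanation for this result.

The compounds shown leave open whether a longer chain, an amine or a carboxylic acid at this place would also hold the number. They also leave open whether ethyl and phenyl would stay this close on other versions of the core.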